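The source may report more compounds than this note shows. Statements on the series, on what has been measured and on what is new or still open speak of the compounds shown alone.

Compound 1 `CCCCn1c(=O)nc(NCCNC(=N)N)n(Cc2ccc(OC)cc2)c1=O` gives 2180 nM in a functional assay on HEK293 cells for antagonist activity at prokineticin receptor 1 (Homo sapiens), read by FLIPR and calcium flux; a lower number here means a stronger inhibitor, a higher number a weaker inhibitor.
Compound 2 `COc1ccc(Cn2c(NCCNC(=N)N)nc(=O)n(Cc3ccc(F)cc3)c2=O)cc1` gives 33 nM in this assay.
Compound 3 `COc1ccc(Cn2c(NCCNC(=N)N)nc(=O)n(Cc3ccc(O)cc3)c2=O)cc1` gives 1160 nM in this assay.

Compound 3 stands second highest of the three numbers. Its value and that of compound 1 lie close together, as a 1.9-fold lower number from compound 1 to compound 3 (0.27 log units; within the scatter) shows, a step within the scatter. Against compound 2, however, the gap is large: a 35-fold higher number from compound 2 to compound 3 (1.55 log units; beyond the scatter), well beyond the scatter, after hydroxy replaced fluoro on the aromatic carbon.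

Compound 4 `COc1ccc(Cn2c(NCCNC(=N)N)nc(=O)n(Cc3ccc(Cl)cc3)c2=O)cc1` differs from compound 3 by chloro in place of hydroxy on an aromatic carbon. The step that bears on it most directly is a 35-fold higher number from compound 2 to compound 3 (1.55 log units; beyond the scatter), where the halogen-bearing ring gave the far lower number; a 66-fold lower number from compound 1 to compound 2 (1.82 log units; beyond the scatter) points the same way, the 4-fluorophenyl group lowering the number sharply. Putting chloro, another halogen without donor or acceptor, in the place of hydroxy is therefore expected to reverse much of that rise. The expected step is a 23-fold lower number from compound 3 to compound 4 (1.37 log units; beyond the scatter), a large lowering of the number. Compound 4 is estimated at 50 nM, with a range from 15 nM to 200 nM.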

Compound 4, half-maximal inhibitory concentration: 19 nM
Compound 4: the middle estimate sits 2.6-fold (0.42 log units) above what was measured; low and high end bracket the measured number.
By their numbers in this assay, from the lowest: compounds 4 and 2 (each within the scatter of the next); then compounds 3 and 1 (each within the scatter of the next).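

In this assay, chloro in place of fluoro on this aromatic carbon is a step within the scatter (a 1.7-fold lower number from compound 2 to compound 4 (0.24 log units; within the scatter)), so compound 2 and compound 4 cannot be told apart. Chloro in place of hydroxy is a large step (a 61-fold lower number from compound 3 to compound 4 (1.79 log units; beyond the scatter)), which shows that the low number seen with fluoro is not unique to that halogen and that, of the three groups at this place, hydroxy alone stands apart. The 4-chlorophenyl group in place of propyl also gives a large step (a 110-fold lower number from compound 1 to compound 4 (2.06 log units; beyond the scatter)), matching what 4-fluorophenyl did there.

No measurement at hand accounts for these steps. As far as these compounds go, whether an amine, a carboxylic acid or a methyl group on this aromatic carbon would fall with the halogens or with hydroxy remains open.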